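The compounds below may be only part of what the source reports. "The series", "measured", "known", "first", "only" and "open" are said of these compounds alone.

Measured so far in an ADME assay on liver (Homo sapiens) for metabolic stability, read by LC-MS, using microsomes and NADPH; a higher number here means that more of the compound is left, a lower number that less of the compound is left:
compound 1 `Cc1cc(CN(CC2CCCCC2)C(CC(=O)O)c2ccc(Cl)cc2)ccc1OCCN1C(=O)CCC1=O` gives 47%
compound 2 `Cc1cc(CN(C)C(CC(=O)O)c2ccc(Cl)cc2)ccc1OCCn1c(=O)ccn(C)c1=O` gives 76%

Compound 2 stands highest of the two numbers; the nearest is compound 1, whose value lies lower by a margin beyond the usual scatter. Within the data shown here, no step between the measured compounds can be read at a single point, since compound 1 and compound 2 differ from each other in more than one place, so the pair shows only that the two values are far apart, with compound 2 on top.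

Compound 3 `Cc1cc(CN(CC2CC2)C(CC(=O)O)c2ccc(Cl)cc2)ccc1OCCn1c(=O)ccn(C)c1=O` has not yet been measured in this assay . The change from compound 2 is cyclopropyl in place of hydrogen on a saturated chain carbon bound to an amine nitrogen. Among the measured compounds shown here, no measured pair separates a hydrogen from a cyclopropyl at that carbon, so the expectation rests on the spread seen between the two measured compounds alone. A downward step of moderate size is expected, a number 14 percentage points lower from compound 2 to compound 3 (beyond the scatter), beyond the scatter but not reaching the level of compound 1. Compound 3 is therefore estimated at 62%, with a range from 45% to 78%.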

Compound 3, percent of the compound remaining: 32%
Beside the measured number, compound 3's estimate is 30 percentage points above it; the whole stated range lies above it.
By their numbers in this assay, from the lowest: compound 3; then compound 1; then compound 2.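

In this assay, among these compounds, this is the first change that can be read at a single place: cyclopropyl in place of hydrogen on a saturated chain carbon bound to an amine nitrogen gives a number 44 percentage points lower from compound 2 to compound 3 (beyond the scatter). The same difference, cut one bond further out, reads methyl to cyclopropylmethyl; it brings in 3 heavy atoms, all carbon, with no hydrogen-bond donors or acceptors and no net charge, so a small addition of this kind at this place is enough to produce a large step. Nothing available on these compounds accounts for the size of the step.

Among the compounds shown here, this single pair gives only one substituent comparison at this carbon, so it remains open whether ethyl, or a longer chain ending in an amine, would leave the number nearer that of compound 2 or that of compound 3. On these data alone, it also remains open whether a step of this size would recur on a compound that differs from compound 2 elsewhere in the structure.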